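Two Urea Sulfonyl Compounds and a Methyl Addition

The compounds below may be only part of what the source reports. "The series", "measured", "known", "first", "only" and "open" are said of these compounds alone.

The measured compounds in a functional assay on HT-29 cells (Homo sapiens) for cytotoxicity, read by sulforhodamine B assay, with a stated time of 48 h (a lower number here means a stronger inhibitor, a higher number a weaker inhibitor), are:

compound 1, `Cc1ccccc1NS(=O)(=O)c1cccc(NC(=O)NCCCCl)c1`, with 42000 nM;
compound 2, `CCc1ccccc1NS(=O)(=O)c1cccc(NC(=O)NCCCCl)c1`, with 96000 nM;
compound 3, `CCNC(=O)Nc1cccc(S(=O)(=O)Oc2ccccc2C)c1`, with 44000 nM.

Compound 1 and compound 2 share a core and differ in one place: methyl in place of hydrogen on a saturated chain carbon bound to an aromatic carbon. This change gave a 2.3-fold higher number from compound 1 to compound 2 (0.36 log units; beyond the scatter), so the methyl addition weakened inhibition by a small but real amount in this assay.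

Compound 3 carries a different core from compound 1; the difference between the two cores is not broken down here. In this assay compound 3 gives a number that sits within the scatter of the number for compound 1, so no order between the two can be drawn. The number for compound 3 is lower than that for compound 2, and that gap lies beyond the scatter.

Compound 4, `CCNC(=O)Nc1cccc(S(=O)(=O)Oc2ccccc2CC)c1`, is not yet measured. It stands to compound 3 as compound 2 stands to compound 1: methyl in place of hydrogen on a saturated chain carbon bound to an aromatic carbon. Since the place of the change is the same, it is the same change, only made on the core of compound 3.

Among the measured compounds shown here, the expectation for compound 4 in this assay rests on the single measured instance of this change, a 2.3-fold higher number from compound 1 to compound 2 (0.36 log units; beyond the scatter). It also rests on the starting point given by compound 3, which shows 44000 nM in this assay. Going by these compounds, whether the same change on a different core behaves the same way is unknown from these data, so the range is kept wide. Compound 4 is therefore estimated at 90000 nM, between 40000 nM and 200000 nM, which is expected to mean a step of a 2.0-fold higher number from compound 3 to compound 4 (0.31 log units; beyond the scatter).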

Compound 4, half-maximal inhibitory concentration: 33000 nM
For compound 4 the middle estimate is 2.7-fold (0.44 log units) above the measured one, outside the stated range (below it).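

In this assay, extending the 2-methylphenyl group to a 2-ethylphenyl group on the core of compound 3 gave a 1.3-fold lower number from compound 3 to compound 4 (0.12 log units; within the scatter), so the two compounds cannot be told apart on this core. The same change therefore did not carry over from the core of compound 1 to the core of compound 3, where it left the number without a real shift: the same change on two cores in this assay, a 2.3-fold higher number (0.36 log units; beyond the scatter) from compound 1 to compound 2 and a 1.3-fold lower number (0.12 log units; within the scatter) from compound 3 to compound 4, 3.0-fold (0.48 log units) apart, beyond the scatter of two such steps This shows that, in this series, the step seen on one core was not a reliable guide to the step on the other; it does not show why the cores behave differently, and with a single pair on each core it gives no rule for any further core.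

Going by these compounds, it remains open whether a longer chain at the same place, such as propyl, or a chain ending in an amine or a carboxylic acid, would follow the step seen on either core. On these data alone, it also remains open which part of the difference between the two cores decides how this change behaves.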